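This account rests on a few compounds, and the source may have more. Where it says the series, first, only, none or still open, it means among the compounds named here.

Working notes on the series. Compound 1 `COc1ccc(CNc2nc([Se]C)nc3ccccc23)cc1` is recorded in an ADME assay on 184B5 cells (Homo sapiens) for cytotoxicity, read by MTT assay, with a stated time of 72 h (a higher number here means a weaker inhibitor of growth, a lower number a stronger inhibitor of growth), only as a limit, > 100000 nM, so its standing rests on the limit of > 100000 nM in this assay, at which 1 of the 3 values shown sits, rather than on a number. Compound 2 `C[Se]c1nc(N)c2ccccc2n1` gives 59000 nM in this assay, and compound 3 `C[Se]c1nc(NCc2ccccc2)c2ccccc2n1` gives 12400 nM. For the measured compounds named here, the one step with a computed size, an at least 8.0-fold lower number from compound 1 to compound 3 (0.90 log units; beyond the scatter), concerns a change at a different position and does not involve the group exchanged here.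

Compound 4 `COc1ccc(CNc2nc(SC)nc3ccccc23)cc1` differs from compound 1 by a group of 2 heavy atoms (1 carbon, 1 sulfur; no ring) in place of a group of 2 heavy atoms (1 carbon, 1 selenium; no ring), on an aromatic carbon. Going by the values given here, no measured step bears on this exchange, so no step beyond the scatter is expected in this assay for compound 4, and a value at or past the limit is expected, a number no higher from compound 1 to compound 4 (the limit leaves the size open). Compound 4 is estimated at 100000 nM, within 40000 nM to 250000 nM.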

Compound 4, concentration for total growth inhibition: > 100000 nM
Compound 4: a limit, no number; the forecaster's own chance of this, stated with the estimate: 60%; the middle value sits exactly at the limit.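

Compound 1 and compound 4 both stand only as limits, so no step between them can be read: the limit of > 100000 nM in this assay, at which 2 of the 4 values shown sit.

The compounds shown leave open whether methylsulfanyl in place of the selenium-bearing group changes growth inhibition at all.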